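The source may report more compounds than this note shows. Statements on the series, on what has been measured and on what is new or still open speak of the compounds shown alone.

Series notes. In a functional assay on DU-145 cells (Homo sapiens) for inhibition, read by MTT assay, with stated times of 18 h and 4 h (on this read-out higher numbers stand for weaker inhibition and lower numbers for stronger inhibition), compound 2 (`CCCCCCCCCCOP(=O)(O)OCCSC(=S)N1CCCCC1`) gives 29300 nM and compound 1 (`CCCCCCCCCCCCCCCCOP(=O)(O)OCCSC(=S)N1CCCCCC1`) gives 17600 nM. Going by the values given here, these are the only two numbers so far, and they lie within the scatter of each other, so compound 2 stands level with compound 1.

Compound 3 (`CCCCCCCCCCCCCCCCOP(=O)(O)OCCSC(=S)N1CCCCC1`) has not yet been measured. It departs from compound 2 by hexyl in place of hydrogen on a saturated chain carbon, ten or more bonds along the chain from an oxygen on an unsaturated carbon. Cut one bond further out, the same difference reads as propyl to nonyl.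

Among the compounds with values here, no measured pair differs in one place, so the series offers no direct step for this change. In this assay, a small move towards a lower number is expected, possibly none beyond the scatter. Within the data shown here, this is a cautious judgement, and the only support is that compound 2 at 29300 nM and compound 1 at 17600 nM show no large spread. The expected move is modest, and the estimated step is a 1.8-fold lower number from compound 2 to compound 3 (0.26 log units; within the scatter). For compound 3 the estimated value is 16000 nM, with an expected range of 7000 nM to 35000 nM.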

Compound 3, half-maximal inhibitory concentration: 14700 nM
Compound 3: middle estimate off by 1.1-fold (0.04 log units), on the high side; the measured number falls inside the stated range.
By their numbers in this assay, from the lowest: compounds 3, 1 and 2 (each within the scatter of the next).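

In this assay, the series now has its first steps that change one place only, and hexyl in place of hydrogen on a saturated chain carbon, ten or more bonds along the chain from an oxygen on an unsaturated carbon, reads as a 2.0-fold lower number from compound 2 to compound 3 (0.30 log units; within the scatter) and so stays inside the scatter. Piperidin-1-yl in place of azepan-1-yl on a thiocarbonyl carbon reads as a 1.2-fold lower number from compound 1 to compound 3 (0.08 log units; within the scatter) and also stays inside it, so on these pairs neither the chain change nor the ring change separates the compounds in this read-out. Nothing available bears on why either step has the size it has.

Open, from the compounds shown here alone, is whether a longer chain than that of compound 3 would carry the number beyond the scatter, and whether a morpholin-4-yl group in place of piperidin-1-yl on the thiocarbonyl carbon would do so. Also open, going by these compounds, is whether an amine or a carboxylic acid on the chain would leave the number as level as the hexyl change does here.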